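The source may hold more compounds than are shown below. What is called first, only, known or untested is meant among the compounds shown, and "the series" means these compounds.

Measured compounds and their values:

Compound 1 `COc1ccc(N/C=C\C(=O)c2nc(-c3ccc(C(F)(F)F)cc3)n3ccccc23)cc1OC` — in a functional assay on MDA-MB-231 cells (Homo sapiens) for cytotoxicity, read by MTT assay, with a stated time of 48 h (on this read-out higher numbers stand for weaker inhibition and lower numbers for stronger inhibition), compound 1 gives > 30000 nM, a limit of the assay.
Compound 2 `COc1ccc(-c2nc(C(=O)/C=C\Nc3ccc(Cl)cc3)c3ccccn23)cc1` — in this assay compound 2 gives > 30000 nM, a limit of the assay.
Compound 3 `COc1ccc(N/C=C\C(=O)c2nc(-c3ccc(F)cc3)n3ccccc23)cc1OC` — in this assay compound 3 gives > 30000 nM, a limit of the assay.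

Compound 1 therefore does not stand at a number at all in this assay: its value is a limit, and the two other measured compounds return the same limit. Among the measured compounds shown here, the one measured step that can be set beside it, a step that the two limits leave unreadable from compound 1 to compound 3, cannot be read in size or direction because both of its ends sit at the limit of > 30000 nM in this assay, at which 3 of the 3 values shown sit. For the measured compounds named here, the pair of compound 1 and compound 2 has no step written for it; their two values show the same limit and nothing more.

The unmeasured compound is compound 4 `O=C(/C=C\Nc1cnc2ccccc2c1)c1nc(-c2ccc(C(F)(F)F)cc2)n2ccccc12`. It differs from compound 1 in one place: quinolin-3-yl in place of 3,4-dimethoxyphenyl on an amine nitrogen. Going by the values given here, no measured step bears on this change with a readable size; all three measured steps end at the limit of > 30000 nM in this assay, at which 3 of the 3 values shown sit. The expectation for compound 4 in this assay therefore rests only on the shared core and the three limits around it, and the expected step of a number no higher from compound 1 to compound 4 (the limit leaves the size open) is none beyond the scatter, with a strong chance that the assay again returns only a limit. The estimate for compound 4 is 30000 nM, with a range from 8000 nM to 100000 nM.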

Compound 4, half-maximal inhibitory concentration: > 30000 nM
Compound 4 gave a limit, no number; the forecaster's own chance of this, stated with the estimate: 75%; the middle value lies on the limit itself.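

In this assay compound 4 gives > 30000 nM which is a limit of the assay and not a number. Among the compounds shown here, no step from compound 1 to compound 4 can be read, as neither has a number: the limit of > 30000 nM in this assay, at which 4 of the 4 values shown sit. The compounds shown leave open how strong any of them is, and whether quinolin-3-yl or 3,4-dimethoxyphenyl on the amine nitrogen makes any difference.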